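Adding a Second Chloro to the Benzyl Group

The compounds below may be only part of what the source reports. "The series", "measured", "known", "first", "only" and "open" are said of these compounds alone.

Three compounds share one core and differ only on the benzyl ring. Compound 1 `Cc1ccc(-c2nn(-c3ccccc3)cc2C(=O)NOCc2ccccc2)cc1` gives 40800 nM in an ADME assay on HEK-293T cells (Homo sapiens) for antiproliferative activity, read by MTT assay, with a stated time of 48 h, in the presence of a further agent that is not named here; on this read-out lower numbers stand for higher toxicity in this test and higher numbers for lower toxicity in this test. Compound 2 `Cc1ccc(-c2nn(-c3ccccc3)cc2C(=O)NOCc2ccccc2F)cc1` gives 20600 nM in this assay, and compound 3 `Cc1ccc(-c2nn(-c3ccccc3)cc2C(=O)NOCc2ccccc2Cl)cc1` gives 38700 nM. Compound 3 stands among numbers that all lie within the scatter of one another: a 1.1-fold lower number from compound 1 to compound 3 (0.02 log units; within the scatter), a 2.0-fold lower number from compound 1 to compound 2 (0.30 log units; within the scatter), and a 1.9-fold higher number from compound 2 to compound 3 (0.27 log units; within the scatter). Compound 4 `Cc1ccc(-c2nn(-c3ccccc3)cc2C(=O)NOCc2ccc(Cl)cc2Cl)cc1` carries one further change: chloro in place of hydrogen on an aromatic carbon. Within the data shown here, the steps that bear on it, a chloro or fluoro entering this ring, each stayed within the scatter, so no step beyond the scatter is expected in this assay. The step from compound 3 to compound 4 is estimated as a 1.0-fold lower number from compound 3 to compound 4 (0.01 log units; within the scatter). Compound 4 is expected to give 38000 nM, between 15000 nM and 90000 nM.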

Compound 4, half-maximal cytotoxic concentration: 39600 nM
Compound 4: middle estimate off by 1.0-fold (0.02 log units), on the low side; low and high end bracket the measured number.
By their numbers in this assay, from the lowest: compounds 2, 3, 4 and 1 (each within the scatter of the next).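

Placing a second chloro on the benzyl ring, para to a large group and meta to the first chloro, stays within the scatter in this assay (a 1.0-fold higher number from compound 3 to compound 4 (0.01 log units; within the scatter)). The 2,4-dichlorobenzyl group also stays within the scatter of the 2-fluorobenzyl group (a 1.9-fold higher number from compound 2 to compound 4 (0.28 log units; within the scatter)) and of the unsubstituted benzyl group (a 1.0-fold lower number from compound 1 to compound 4 (0.01 log units; within the scatter)). No evidence is available that bears on this result.

Still open, going by these compounds, is whether an amine or a carboxylic acid at this position would give a step beyond the scatter.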